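Butyl in place of phenyl: compound 3 to compound 4

This account rests on a few compounds, and the source may have more. Where it says the series, first, only, none or still open, it means among the compounds named here.

In a functional assay on HeLa cells (Homo sapiens) for cytotoxicity, read by MTT assay (a higher number here means a weaker inhibitor, a lower number a stronger inhibitor), compound 1 `CCCC(O)CC(=O)O[C@H](CC=C(C)C)C1=CC(=O)c2c(O)ccc(O)c2C1=O` gives 59300 nM, compound 2 `CCC(CO[C@H](CC=C(C)C)C1=CC(=O)c2c(O)ccc(O)c2C1=O)OC(C)=O` gives 44000 nM, and compound 3 `CC(C)=CC[C@@H](OC(=O)CC(C)(O)c1ccccc1)C1=CC(=O)c2c(O)ccc(O)c2C1=O` gives 85700 nM. All three stand within the scatter of one another. Compound 4 `CCCCC(C)(O)CC(=O)O[C@H](CC=C(C)C)C1=CC(=O)c2c(O)ccc(O)c2C1=O`, not yet measured, differs from compound 3 by butyl in place of phenyl on a saturated chain carbon bound to an oxygen on a saturated carbon and two saturated chain carbons, with butyl in place of phenyl on a saturated chain carbon bound to an oxygen on a saturated carbon and two saturated chain carbons. The closest evidence is a 1.4-fold higher number from compound 1 to compound 3 (0.16 log units; within the scatter), the step that brought in the phenyl. It stayed within the scatter, as did a 1.3-fold lower number from compound 1 to compound 2 (0.13 log units; within the scatter). No step beyond the scatter is therefore expected in this assay. The estimated step is a 1.4-fold lower number from compound 3 to compound 4 (0.15 log units; within the scatter). For compound 4 the expected value is 60000 nM, with an estimated range of 30000 nM to 115000 nM.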

Compound 4, half-maximal inhibitory concentration: 60600 nM
Estimate against measurement, compound 4: 1.0-fold (0.00 log units) below; measured number inside the range.
By their numbers in this assay, from the lowest: compounds 2, 1, 4 and 3 (each within the scatter of the next).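

In this assay the butyl that takes the place of phenyl on this saturated chain carbon gives a 1.4-fold lower number from compound 3 to compound 4 (0.15 log units; within the scatter) and so shows that an open chain can stand here instead of the aromatic ring without a step beyond the scatter. The other new steps, a 1.0-fold higher number from compound 1 to compound 4 (0.01 log units; within the scatter) and a 1.4-fold higher number from compound 2 to compound 4 (0.14 log units; within the scatter), also stay within the scatter. No evidence at hand explains this flat picture. From the compounds shown here alone, whether an amine or a carboxylic acid on this carbon would bring a step beyond the scatter remains open, as does the outcome for a chain longer than butyl.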